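Replacing the Benzamido Group of Compound 2

The source may hold more compounds than are shown below. What is called first, only, known or untested is meant among the compounds shown, and "the series" means these compounds.

Compound 1 `Cn1cc(C#N)c2ccc(Nc3ncc(-c4ccc(CN)cc4)o3)cc21`: 2800 nM
Compound 2 `Cn1cc(C#N)c2ccc(Nc3ncc(-c4cccc(NC(=O)c5ccccc5)c4)o3)cc21`: 3500 nM

In a functional assay on CCRF-CEM cells (Homo sapiens) for inhibition (on this read-out lower numbers stand for stronger inhibition and higher numbers for weaker inhibition), compound 2 stands at 3500 nM, within the scatter of compound 1 at 2800 nM. Compound 3 `Cn1cc(C#N)c2ccc(Nc3ncc(-c4cccc(CNC(=O)OCCC#N)c4)o3)cc21` has not yet been measured. It carries (((2-cyanoethoxy)carbonyl)amino)methyl in place of benzamido on an aromatic carbon. Going by the values given here, no measured step between closely matched compounds is available. With compound 1 at 2800 nM and compound 2 at 3500 nM, no change beyond the scatter is expected in this assay. The expected step is a 1.2-fold lower number from compound 2 to compound 3 (0.07 log units; within the scatter). For compound 3 the estimated value is 3000 nM, with a range of 1000 nM to 9000 nM.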

Compound 3, half-maximal inhibitory concentration: > 10000 nM
Compound 3: only a limit was reported (the forecaster's own chance of this, stated with the estimate: 10%); at least 3.3-fold (0.52 log units) between middle value and limit.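

In this assay, this aromatic carbon proves not to accept every group of the same size: (((2-cyanoethoxy)carbonyl)amino)methyl and benzamido both have 9 heavy atoms, yet the replacement gives an at least 2.8-fold higher number from compound 2 to compound 3 (0.45 log units; beyond the scatter). From the compounds shown here alone, the value of compound 3, > 10000 nM, is a limit and not a number, so the full size of this step stays unknown: the limit of > 10000 nM in this assay, at which 1 of the 3 values shown sits.

The compounds shown leave open whether the loss follows from removing the benzene ring or from the chain that enters. An acetamido group or a carboxylic acid on this carbon would be untested here.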